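Dropping the Chloro Group: From Compound 2 to Compound 3

This account rests on a few compounds, and the source may have more. Where it says the series, first, only, none or still open, it means among the compounds named here.

Within the data shown here, compound 2 `COc1cc(OC)c(NC(=O)Cc2nn(CC(=O)O)c(=O)c3ccccc23)cc1Cl` is one of two compounds measured so far in a functional assay on CHO cells for agonist activity at sphingosine 1-phosphate receptor 2 (Homo sapiens), read by calcium flux; on this read-out lower numbers stand for stronger inhibition and higher numbers for weaker inhibition. For compound 2 this assay reports only a limit, > 23300 nM. Compound 1 `COc1ccc(Cl)cc1NC(=O)Cc1nn(CC(=O)O)c(=O)c2ccccc12` likewise returns only a limit, > 23300 nM. The step that the two limits leave unreadable from compound 1 to compound 2 cannot be read, because of the limit of > 23300 nM in this assay, at which 2 of the 2 values shown sit. Compound 3 `COc1ccc(NC(=O)Cc2nn(CC(=O)O)c(=O)c3ccccc23)c(OC)c1` differs from compound 2 by hydrogen in place of chloro on an aromatic carbon. No readable measured step bears on this change, so no direction beyond the scatter is expected, and a further limit is the most likely outcome. Compound 3 is expected to give 30000 nM, spanning 8000 nM to 120000 nM. The step this estimate means is expected to be a step that the limit leaves unreadable from compound 2 to compound 3.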

Compound 3, half-maximal inhibitory concentration in the sphingosine 1-phosphate receptor 2 assay: > 23300 nM
Compound 3 was reported as a limit (the forecaster's own chance of this, stated with the estimate: 85%); the middle value lies beyond the limit too.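

In the sphingosine 1-phosphate receptor 2 assay compound 2 returns only a limit, > 23300 nM. In the sphingosine 1-phosphate receptor 2 assay compound 3 also returns only a limit, > 23300 nM. No new step can be read here: the limit of > 23300 nM in the sphingosine 1-phosphate receptor 2 assay, at which 3 of the 3 values shown sit.

In a physicochemical assay for lipophilicity, at pH 7.4 (on this read-out lower numbers stand for lower lipophilicity and higher numbers for higher lipophilicity), compound 2 gives 1.64. In the physicochemical assay compound 3 gives 1.13, a number 0.51 log units lower from compound 2 to compound 3 (beyond the scatter).

Whether the chloro group matters in the sphingosine 1-phosphate receptor 2 assay, and how strongly any of these compounds acts there, stays open.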